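Swapping a Hydroxymethyl for a Sulfonamide on the Core

The compounds below may be only part of what the source reports. "The series", "measured", "known", "first", "only" and "open" are said of these compounds alone.

Compound 1 `CCCCN(c1nc2c(CO)cccc2o1)[C@H](C)c1ccc(-c2ccccc2-c2nnn[nH]2)cc1` was tested in an ADME assay on the whole organism (Macaca fascicularis) for pharmacokinetics, read by LC-MS, using cassette dosing, at a dose of 1 mg/kg by the oral route (a lower number here means less compound in the circulation, a higher number more compound in the circulation at the dose given), where compound 1 gives 20.7 nM. This is the lowest of the three numbers measured. Compound 3 `CCCCN(c1nc2c(C(=O)O)cccc2o1)[C@H](C)c1ccc(-c2cc(Cl)ccc2-c2nc(=O)o[nH]2)cc1` gives 677 nM, and compound 2 `C[C@H](c1ccc(-c2cc(F)ccc2-c2nc(=O)o[nH]2)cc1)N(CC1CC1)c1nc2c(C(=O)O)cccc2o1` gives 2900 nM; both lie well above compound 1, beyond the usual scatter, but each differs from compound 1 in several places at once, so no single change can be read from them. Compound 4 `CCCCN(c1nc2c(NS(C)(=O)=O)cccc2o1)[C@H](C)c1ccc(-c2ccccc2-c2nnn[nH]2)cc1` differs from compound 1 in one place: methanesulfonamido in place of hydroxymethyl on an aromatic carbon. Among the compounds with values here, no measured pair shows this change alone. The step is expected to be a modest rise that may not exceed the scatter, a 1.7-fold higher number from compound 1 to compound 4 (0.23 log units; within the scatter). Compound 4 is therefore estimated at 35 nM, within the range 8 nM to 150 nM.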

Compound 4, maximal plasma concentration: 49.9 nM
The estimate for compound 4 lay 1.4-fold (0.15 log units) below the measured number; the measured number falls inside the stated range.
By their numbers in this assay, from the lowest: compound 1; then compound 4; then compound 3; then compound 2.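

Within the data shown here, this is the first change at this place on the shared core that can be read alone: methanesulfonamido in place of hydroxymethyl gives a 2.4-fold higher number from compound 1 to compound 4 (0.38 log units; beyond the scatter) in this assay and so a modest gain rather than a loss. The larger group on this aromatic carbon therefore leaves more compound in the circulation, not less. Nothing available explains this rise.

From the compounds shown here alone, whether a simple amine or a primary amide at this place would give a higher number remains open. So does whether this step would hold with the other parts of the molecule changed.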